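Lengthening the Chain on a Two-Compound Series

The source may report more compounds than this note shows. Statements on the series, on what has been measured and on what is new or still open speak of the compounds shown alone.

Measured compounds:
compound 1, `CCCCC1Nc2ccccc2C(=O)N1Cc1ccc(-c2ccccc2-c2nn[nH]n2)cc1`, 14000 nM
compound 2, `CCCC1Nc2ccc(C(C)C)cc2C(=O)N1Cc1ccc(-c2ccccc2-c2nn[nH]n2)cc1`, 50 nM

Of the compounds shown here, two have been measured in an assay on adrenal cortex for inhibition of angiotensinogen (Rattus norvegicus); a higher number here means a weaker inhibitor, a lower number a stronger inhibitor. Compound 1 gives 14000 nM. Compound 2 gives 50 nM, the lower of the two numbers, and the gap between compound 1 and compound 2 lies well beyond the usual scatter. The two compounds differ in two places at once, so what each difference contributes on its own cannot be read from these numbers.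

Compound 3, `CCCCC1Nc2ccc(C(C)C)cc2C(=O)N1Cc1ccc(-c2ccccc2-c2nn[nH]n2)cc1`, has not yet been measured. It differs from compound 2 in one place: methyl in place of hydrogen on a saturated chain carbon, three bonds along the chain from a saturated ring carbon. Going by the values given here, no measured pair in this set isolates this change, so no direct precedent exists for its size. On the evidence available, the step from compound 2 to compound 3 is expected to be small, and plausibly within the usual scatter, as a 1.2-fold higher number from compound 2 to compound 3 (0.08 log units; within the scatter) expresses. Compound 3 is therefore estimated at 60 nM in this assay, with a range from 15 nM to 250 nM.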

Compound 3, half-maximal inhibitory concentration: 1100 nM
Compound 3: middle estimate off by 18-fold (1.26 log units), on the low side; measured number outside the range, above it.
By their numbers in this assay, from the lowest: compound 2; then compound 3; then compound 1.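

In this assay, the step from a propyl to a butyl chain adds a single methyl at the chain end, yet it gives a 22-fold higher number from compound 2 to compound 3 (1.34 log units; beyond the scatter). This position therefore responds strongly to a one-carbon change in chain length, at least with isopropyl on the aromatic carbon, and compound 2 with its propyl chain holds the lower number. Going by these compounds alone, compound 3 also isolates the other change for the first time, since with the butyl chain held fixed, isopropyl in place of hydrogen on the aromatic carbon gives a 13-fold lower number from compound 1 to compound 3 (1.10 log units; beyond the scatter), so each of the two single changes has a large effect of its own, and nothing available explains either one.

On these data alone, only propyl and butyl chains have been compared here, so it stays open whether an ethyl chain or a branched isobutyl chain would give a lower or a higher number than propyl. As far as these compounds go, it is also open whether a methyl, a chlorine atom or a tert-butyl on that aromatic carbon would match isopropyl, and whether the chain behaves the same way with hydrogen there.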